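This account rests on a few compounds, and the source may have more. Where it says the series, first, only, none or still open, it means among the compounds named here.

In a functional assay on MIA PaCa-2 cells (Homo sapiens) for cytotoxicity, read by MTT assay, with a stated time of 72 h (on this read-out lower numbers stand for an effect already at smaller amounts and higher numbers for an effect only at larger amounts of compound), compound 1 (`O=C1/C(=C\c2c(Cl)cccc2Cl)c2ccccc2N1c1c(Cl)cccc1Cl`) gives > 100 ug/mL as a limit of the assay, not a number. Compound 2 (`O=C1/C(=C\c2cc3ccccc3nc2Cl)c2ccccc2N1c1c(Cl)cccc1Cl`) gives 5 ug/mL and compound 3 (`O=C1/C(=C\c2ccc(F)cc2)c2ccccc2N1c1c(Cl)cccc1Cl`) gives 5 ug/mL and so stands level with it. Compound 4 (`O=C1/C(=C\c2ccc(Cl)cc2)c2ccccc2N1c1c(Cl)cccc1Cl`) matches compound 3 except in one place, with chloro in place of fluoro on an aromatic carbon, para to a large group (chloro in place of fluoro on an aromatic carbon). Going by the values given here, only one measured step touches this group. It is large and beyond the scatter, an at least 20-fold lower number from compound 1 to compound 3 (1.30 log units; beyond the scatter) with 4-fluorophenyl taking the place of 2,6-dichlorophenyl. The change from 4-fluorophenyl to 4-chlorophenyl is a much smaller swap than that one, so the large step says little about its size. No shift beyond the scatter is therefore expected in this assay in either direction. The expected outcome is no change at the digits printed from compound 3 to compound 4 (within the scatter) and this would leave the two compounds level. The estimated value for compound 4 is 5 ug/mL with an expected range from 2 ug/mL to 14 ug/mL in this read-out.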

Compound 4, concentration for half-maximal effect: 5 ug/mL
Estimate against measurement, compound 4: no gap at the digits printed; the range from low to high includes it.
By their numbers in this assay, from the lowest: compounds 2, 3 and 4 (each within the scatter of the next). At a limit, above all of these: compound 1.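

In this assay, the swap of fluoro for chloro on an aromatic carbon, para to a large group, gives no change at the digits printed from compound 3 to compound 4 (within the scatter), so this position takes either group with no visible difference in this read-out. Going by these compounds alone, until now, fluoro was the only group seen at this place, whereas the 4-chlorophenyl compound gives an at least 20-fold lower number from compound 1 to compound 4 (1.30 log units; beyond the scatter), so the large step away from 2,6-dichlorophenyl now appears with a second group as well. Compound 1 stands at a limit of the assay rather than a number, so this step gives only a minimum size: the limit of > 100 ug/mL in this assay, at which 1 of the 4 values shown sits.

The compounds shown leave open whether a group of another kind at this place, such as a methoxy group, an amine or a carboxylic acid, would stay level in this assay. They also leave open what a plain phenyl ring would give, without fluoro or chloro.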